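Moving a Halogen on a Vinyl Sulfone Series

This account rests on a few compounds, and the source may have more. Where it says the series, first, only, none or still open, it means among the compounds named here.

Compound 1 `O=S(=O)(/C=C/c1ccncc1)c1ccccc1F`: 760 nM
Compound 2 `O=S(=O)(/C=C/c1ccncc1)c1cccc(F)c1`: 950 nM
Compound 3 `O=S(=O)(/C=C/c1ccncc1)c1ccccc1Cl`: 781 nM

These three compounds were measured in an assay on U2OS cells for activation of nuclear factor erythroid 2-related factor 2 (Homo sapiens), read by beta-arrestin recruitment, with a stated time of 6 h; on this read-out higher numbers stand for an effect only at larger amounts of compound and lower numbers for an effect already at smaller amounts. Compound 1 gives 760 nM, compound 2 gives 950 nM, and compound 3 gives 781 nM in this assay. Compounds 1 and 2 are built from the same atoms joined differently; the difference between the two cores is not broken down here. All three numbers lie within the scatter of one another, so no order among them can be read.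

One change has been measured once: chloro in place of fluoro on an aromatic carbon It gave a 1.0-fold higher number from compound 1 to compound 3 (0.01 log units; within the scatter). The same kind of change leads from compound 2 to compound 4 `O=S(=O)(/C=C/c1ccncc1)c1cccc(Cl)c1`: chloro in place of fluoro on an aromatic carbon The two places differ in their surroundings: in compound 1 the exchanged group sits ortho to a large group, in compound 2 meta to a large group. Because a 1.0-fold higher number from compound 1 to compound 3 (0.01 log units; within the scatter) stayed within the scatter, a step of similar size is expected here, no change at the digits printed from compound 2 to compound 4 (within the scatter). Compound 4 is therefore estimated at 950 nM in this assay, with an expected range from 400 nM to 2300 nM.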

Compound 4, half-maximal effective concentration: 528 nM
Estimate against measurement, compound 4: 1.8-fold (0.26 log units) above, within the range that was stated.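

In this assay, chloro in place of fluoro on an aromatic carbon gave a 1.8-fold lower number from compound 2 to compound 4 (0.26 log units; within the scatter), so this step, like the earlier one, is no larger than the differences expected between repeated measurements. Set side by side, the two steps do not differ by more than that scatter allows: the same change on two cores in this assay, a 1.0-fold higher number (0.01 log units; within the scatter) from compound 1 to compound 3 and a 1.8-fold lower number (0.26 log units; within the scatter) from compound 2 to compound 4, 1.8-fold (0.27 log units) apart, within the scatter of two such steps In these two pairs, then, the change carries from one core to the other without a readable effect on the number, but this does not show that the change has no effect or that the two cores respond alike, as a small real difference could still hide inside the scatter and two pairs make no general rule.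

The compounds shown carry only a fluoro or a chloro group on the six-membered aromatic ring of carbon only. From the compounds shown here alone, what a methoxy group, an amine or a carboxylic acid on that ring would do remains open, as does whether any such group would move the number beyond the scatter.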